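A few compounds are considered here, and "the series" means these few. Any claim that something is new, unique, unknown or untested is made for them only; others in the source may bear on it.

Values in a physicochemical assay for lipophilicity; on this read-out lower numbers stand for lower lipophilicity and higher numbers for higher lipophilicity:

- compound 1 `CC(C)(c1cc([C@@]23CCOC[C@@H]2C3)nc(-c2cccc(O)c2)n1)S(C)(=O)=O`, 4.8
- compound 2 `Oc1cccc(-c2nccc([C@@]34CCOC[C@@H]3C4)n2)c1`, 4

Compound 2, at 4, holds the lower of the two measured values, and its gap to compound 1 lies beyond the scatter. The next compound to be measured is compound 3 `Oc1cccc(-c2nccc([C@]34CCOC[C@H]3C4)n2)c1`, and the structural change is the two compounds have the same atoms and bonds and differ only in configuration as drawn: 2 of 2 stereo elements differ (all stereocentres are inverted: mirror images); a stereocentre at a saturated ring carbon is drawn S in compound 2 and R in compound 3; a stereocentre at a saturated ring carbon is drawn R in compound 2 and S in compound 3. Going by the values given here, the only measured step, a number 0.80 log units lower from compound 1 to compound 2 (beyond the scatter), swaps 1-methyl-1-(methylsulfonyl)ethyl for hydrogen on an aromatic carbon. Among the compounds with values here, it therefore gives no direct guide to an inversion of stereocentres, and no mirror-image pair has yet been measured here. Since mirror images share the same atoms and bonds, no step beyond the scatter is expected in this assay, in either direction. The expected result is no change at the digits printed from compound 2 to compound 3 (within the scatter). Compound 3 is estimated at 4, with an expected range from 3.8 to 4.2.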

Compound 3, partition coefficient: 4
Compound 3: middle estimate and measured number agree at the digits printed, within the range that was stated.
By their numbers in this assay, from the lowest: compounds 2 and 3 (each within the scatter of the next); then compound 1.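

In this assay, going by these compounds alone, inverting both stereocentres gives no change at the digits printed from compound 2 to compound 3 (within the scatter), the first measured comparison of mirror images. The earlier step concerned a group on an aromatic carbon, whereas this one leaves every atom and bond in place, so it tests configuration alone, and the read-out does not separate the two forms. The comparison is clean because nothing else distinguishes the pair: the fact that compounds 2 and 3 differ only in the configuration as drawn.

The compounds shown leave open whether the same inversion would also fall within the scatter with 1-methyl-1-(methylsulfonyl)ethyl on the aromatic carbon, as in compound 1. They also leave open where an amine or a carboxylic acid in place of the hydrogen on that aromatic carbon would stand in this assay.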